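This account rests on a few compounds, and the source may have more. Where it says the series, first, only, none or still open, it means among the compounds named here.

Measured compounds:
- compound 1 `CCCCCCCCCCCCCCCCCC(=O)N1CCOCC1`: 39.9 ug/mL
- compound 2 `CCCCCCCCCCCCCCCC(=O)N1CCCC1`: 4.6 ug/mL
- compound 3 `CCCCC/C=C\C/C=C\CCCCCCCC(=O)N1CCCCC1`: 44.2 ug/mL

In a functional assay on U-251 cells (Homo sapiens) for antiproliferative activity, read by sulforhodamine B assay, with a stated time of 48 h (a lower number here means a stronger inhibitor of growth, a higher number a weaker inhibitor of growth), compound 2 gives the lowest number of the three; compound 1 and compound 3 both stand well beyond the scatter above it, and their own two values lie within the scatter of each other. Among the compounds with values here, no direct pair differing in one place has been measured, so nothing is known yet about how a single change moves this read-out.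

Compound 4 `CCCCCCCCCCCCCCCC(=O)N1CCOCC1` is the next compound for this assay. Relative to compound 2 the change is morpholin-4-yl in place of pyrrolidin-1-yl on a carbonyl carbon.

Among the measured compounds, compound 1 also carries the morpholin-4-yl amide, and in this assay compound 1 gives 39.9 ug/mL, a number far weaker than compound 2. The expectation is therefore a step in the weakening direction, beyond the scatter, of about a 5.4-fold higher number from compound 2 to compound 4 (0.74 log units; beyond the scatter). For compound 4 the estimate is 25 ug/mL, with a likely range from 8 ug/mL to 70 ug/mL.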

Compound 4, concentration for 50% growth inhibition: 25 ug/mL
Compound 4: the middle estimate sits on the measured number at the digits printed; the range from low to high includes it.
By their numbers in this assay, from the lowest: compound 2; then compounds 4, 1 and 3 (each within the scatter of the next).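

Within the data shown here, the first comparison in one place in this assay shows that this position on the carbonyl carbon responds to the amide ring: morpholin-4-yl in place of pyrrolidin-1-yl gives a 5.4-fold higher number from compound 2 to compound 4 (0.74 log units; beyond the scatter). Hydrogen in place of ethyl on a saturated chain carbon gives a 1.6-fold lower number from compound 1 to compound 4 (0.20 log units; within the scatter), so with morpholin-4-yl in place this chain change does not separate the two compounds. No measurement on hand accounts for the step at the carbonyl carbon.

Open, from the compounds shown here alone, is whether the step follows the ring oxygen or the ring size: a piperidin-1-yl amide carrying the saturated chain of compound 2 would separate the two. Also open, going by these compounds, is whether the chain change stays as small with pyrrolidin-1-yl in place.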